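A few compounds are considered here, and "the series" means these few. Any claim that something is new, unique, unknown or untested is made for them only; others in the source may bear on it.

In a functional assay on a cell-free system (Platelet, plasma, Homo sapiens), with stated times of 4 min and 5.5 min, tested at 0.125 uM (on this read-out lower numbers stand for a stronger effect and higher numbers for a weaker effect at the one concentration tested), the measured compounds are: compound 1 `O=C(c1ccc[n+](Cc2ccc(Br)cc2)c1)N1CCN(c2ccccc2Cl)CC1` with 84%; compound 2 `O=C(C1CCCN(Cc2ccc(F)cc2)C1)N1CCN(c2ccccc2Cl)CC1` with 100%.

Compound 2 stands highest of the two numbers; its nearest neighbour is compound 1, whose value in this assay lies lower by a gap beyond the scatter. Among the compounds with values here, no step between measured compounds is known, so the two values speak only for themselves. Compound 3 `O=C(C1CCCN(Cc2ccc(Br)cc2)C1)N1CCN(c2ccccc2Cl)CC1` differs from compound 2 in one place: bromo in place of fluoro on an aromatic carbon. With nothing measured for this change, the step from compound 2 to compound 3 is expected to be small, downward if at all, a number 7 percentage points lower from compound 2 to compound 3 (within the scatter). Compound 3 is estimated at 93%, within a range of 75% to 105%.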

Compound 3, a percentage reported as activity, at one concentration (the size of the read-out at that concentration, not a potency): 53%
The estimate for compound 3 lay 40 percentage points above the measured number; measured number below the stated range.
By their numbers in this assay, from the lowest: compound 3; then compound 1; then compound 2.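

In this assay bromo in place of fluoro on the aromatic carbon, para to a large group, gives a number 47 percentage points lower from compound 2 to compound 3 (beyond the scatter) and thus a clearly stronger effect. This shows that the read-out is sensitive to this one position and that a single exchange of halogen there is enough to produce a large step. No measurement at hand accounts for the size of this step.

Going by these compounds, whether chloro, methyl or methoxy on the same carbon would behave more like fluoro or like bromo stays open. So does the effect of fluoro in place of bromo in compound 1.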